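The source may hold more compounds than are shown below. What is called first, only, known or untested is meant among the compounds shown, and "the series" means these compounds.

Measured so far in a functional assay on HepG2 cells (Homo sapiens) for antiproliferative activity, read by MTT assay, with a stated time of 48 h; on this read-out higher numbers stand for weaker inhibition and lower numbers for stronger inhibition:
Compound 1 `CCN(CC)CCNC(=O)c1ccc(C(CC)(CC)c2ccc(OCCC(O)(CC)CC)c(C)c2)n1CC` gives 230 nM.
Compound 2 `CCn1c(C(=O)NCC#N)ccc1C(CC)(CC)c1ccc(OCCC(O)(CC)CC)c(C)c1` gives only a limit, > 50000 nM.
Not yet measured: compound 3 `CCn1c(C(=O)NC(CC(=O)O)C(=O)OC)ccc1C(CC)(CC)c1ccc(OCCC(O)(CC)CC)c(C)c1`.

Compound 2 stands at the edge of what this assay reports: its number is a limit, (the limit of > 50000 nM in this assay, at which 1 of the 2 values shown sits), and not a measured value. For the measured compounds named here, the only measured step, an at least 210-fold higher number from compound 1 to compound 2 (2.33 log units; beyond the scatter), ends at that limit.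

The change to compound 3 is a group of 9 heavy atoms (5 carbon, 4 oxygen; no ring) in place of a group of 3 heavy atoms (2 carbon, 1 nitrogen; no ring), on an amide-type nitrogen. The new group carries a carboxylic acid and a methyl ester where compound 2 carried a nitrile.

Going by the values given here, only the step from compound 1 to compound 2 bears on this, and it does so indirectly: it shows that removing the (diethylamino)methyl group from this position of the amide cost a large amount of activity, and compound 3 does not restore that group. Among the compounds with values here, no measured step tells what an acidic side chain does at this position. The working expectation is therefore that compound 3 stays weak, near the limit, with the step of an at least 1.2-fold lower number from compound 2 to compound 3 (0.09 log units; that floor lies within the scatter) expected to be small and quite possibly unresolved.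

Compound 3 is estimated at 40000 nM, with a range from 8000 nM to 200000 nM.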

Compound 3, half-maximal inhibitory concentration: 10700 nM
For compound 3 the middle estimate is 3.7-fold (0.57 log units) above the measured one; measured number inside the range.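

In this assay, the side chain on the amide-type nitrogen still matters once the diethylamino group is gone, with an at least 4.6-fold lower number from compound 2 to compound 3 (0.66 log units; beyond the scatter). Compound 2 gives a limit and not a measured value, so the size of that step is only a floor: the limit of > 50000 nM in this assay, at which 1 of the 3 values shown sits. Even so, the new group does not reach the level of the diethylamino-bearing chain, with a 47-fold higher number from compound 1 to compound 3 (1.67 log units; beyond the scatter), which leaves that chain the most active of the three side chains shown on this nitrogen.

Which part of the new group accounts for the lower number stays open, as the carboxylic acid and the methyl ester enter together, and a side chain carrying only one of them, or a plain ethyl group, would separate their contributions. Also open, from the compounds shown here alone, is how much of the level of compound 1 depends on the diethylamino group itself, which a dimethylamino or pyrrolidine end, or a longer chain ending in the same amine, on this amide-type nitrogen would help to settle.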